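Working notes on a side-chain exchange in the series

A few compounds are considered here, and "the series" means these few. Any claim that something is new, unique, unknown or untested is made for them only; others in the source may bear on it.

Compound 2 `N#CNC(=N)NCCCCCn1nc(-c2ccccc2)ccc1=O` has been tested in a functional assay on the whole organism (stomach) with Rattus norvegicus as the target; on this read-out lower numbers stand for an effect already at smaller amounts and higher numbers for an effect only at larger amounts of compound. Compound 2 returns only a limit there, > 100 mg/kg, not a number. Compound 1 `C/N=C(/NC#N)NCCCCn1nc(N(C)C)ccc1=O` likewise returns only a limit in this assay, > 100 mg/kg. Within the data shown here, both readings therefore sit at the limit of > 100 mg/kg in this assay, at which 2 of the 2 values shown sit, and no step between measured compounds can be drawn from them.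

Compound 3 `C/N=C(\S)NCCCCCn1nc(-c2ccccc2)ccc1=O` remains to be measured in this assay. It differs from compound 2 by a group of 4 heavy atoms (2 carbon, 1 nitrogen, 1 sulfur; no ring) in place of a group of 5 heavy atoms (2 carbon, 3 nitrogen; no ring), on an amine nitrogen. Among the measured compounds shown here, with no measured step available to scale this change, no shift beyond the usual scatter is expected, and the step from compound 2 to compound 3 is estimated as a number no higher from compound 2 to compound 3 (the limit leaves the size open). For compound 3 the estimate in this assay is 100 mg/kg, with a range from 40 mg/kg to 250 mg/kg, and the result is expected most likely to be a limit again rather than a number.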

Compound 3, dose for half-maximal effect: 35.3 mg/kg
Estimate against measurement, compound 3: 2.8-fold (0.45 log units) above, outside the stated range (below it).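

In this assay, among these compounds, the exchange on the amine nitrogen yields an at least 2.8-fold lower number from compound 2 to compound 3 (0.45 log units; beyond the scatter) and so gives the series its first step that can be read, where the earlier compounds offered only limits. With the rest of the structure unchanged, the result at this position depends on the group it carries: the group of 4 heavy atoms (2 carbon, 1 nitrogen, 1 sulfur; no ring) gives a number, and the group of 5 heavy atoms (2 carbon, 3 nitrogen; no ring) gives a limit. The step is a bound rather than a full size because compound 2 carries only a limit: the limit of > 100 mg/kg in this assay, at which 2 of the 3 values shown sit.

The compounds shown do not separate the sulfur atom from the rest of the entering group. They also leave open how this position behaves with an amine or a carboxylic acid in its place, and whether the step holds on a longer chain.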